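The source may report more compounds than this note shows. Statements on the series, on what has been measured and on what is new or still open speak of the compounds shown alone.

Of the compounds shown here, three sharing one core have been measured in an ADME assay on Raji cells (Homo sapiens) for cytotoxicity, read by CellTiter-Glo and resazurin assay, with a stated time of 72 h; on this read-out lower numbers stand for an effect already at smaller amounts and higher numbers for an effect only at larger amounts of compound. Compound 1 `CC(C)N(Cc1cccc(OCCCCCC(=O)O)c1)C(=O)c1ccc(-c2cccc(OCc3ccccc3)c2)cc1` carries a benzyloxy group on the outer ring; in this assay compound 1 gives > 26000 nM, which is a limit of the assay rather than a number. Compound 2 `CCOc1cccc(-c2ccc(C(=O)N(Cc3cccc(OCCCCCC(=O)O)c3)C(C)C)cc2)c1` has ethoxy at the same spot, and in this assay compound 2 gives > 20800 nM, again only a limit. Compound 3 `CC(C)N(Cc1cccc(OCCCCCC(=O)O)c1)C(=O)c1ccc(-c2cccc(Cl)c2)cc1`, the starting point here, bears a chloro group there, and in this assay compound 3 gives > 21900 nM, also a limit. Since each of these values is a limit, as shown by the limit of > 20800 nM in this assay, at which 1 of the 3 values shown sits, the limit of > 21900 nM in this assay, at which 1 of the 3 values shown sits, and (the limit of > 26000 nM in this assay, at which 1 of the 3 values shown sits), the steps between them cannot be read: a step that the two limits leave unreadable from compound 1 to compound 2, a step that the two limits leave unreadable from compound 1 to compound 3 and a step that the two limits leave unreadable from compound 2 to compound 3 all remain of unknown size. Compound 3 thus stands alongside the other two, none distinguishable from another.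

The next compound, compound 4 `CC(C)N(Cc1cccc(OCCCCCC(=O)O)c1)C(=O)c1ccc(-c2cccc(S(C)(=O)=O)c2)cc1`, differs from compound 3 by one change: methylsulfonyl in place of chloro on an aromatic carbon. Going by the values given here, no measured step bears readably on this change, since every comparison available is between two limits. The expectation for compound 4 is therefore that it too shows no cytotoxic effect within the range tested, with the step that the limit leaves unreadable from compound 3 to compound 4 estimated as none beyond the scatter. Compound 4 is estimated at 25000 nM, within a range from 10000 nM to 100000 nM.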

Compound 4, half-maximal effective concentration: > 26000 nM
Compound 4 gave a limit, no number (the forecaster's own chance of this, stated with the estimate: 85%); middle value at least 1.0-fold (0.01 log units) from the limit.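

Compound 4, like compound 1, compound 2 and compound 3, gives only a limit in this assay, so no step between compound 4 and any of them can be read: the limit of > 26000 nM in this assay, at which 2 of the 4 values shown sit.

The compounds shown leave open at what amount, if any, each would affect these cells, and whether the group that differs among them matters for that effect.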